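Aryl-for-aryl exchange on the chain carbon: compound 4

A few compounds are considered here, and "the series" means these few. Any claim that something is new, unique, unknown or untested is made for them only; others in the source may bear on it.

Compound 1 `Nc1nc(O)c2c(n1)n(C1OC(CO)[C@@H](O)[C@H]1O)c(=O)n2CC(O)CO` carries a 1,2-dihydroxyethyl group on a saturated chain carbon bound to an aromatic nitrogen, and in a functional assay (B cells) with Mus musculus as the target (a lower number here means that less compound is needed, a higher number that more compound is needed for the effect), compound 1 gives 45 uM. Compound 2 `CN(C)CCCn1c(=O)n(C2OC(CO)[C@@H](O)[C@H]2O)c2nc(N)nc(O)c21` gives 194 uM in this assay, the step being a 4.3-fold higher number from compound 1 to compound 2 (0.63 log units; beyond the scatter). Compound 3 `N#Cc1cccc(Cn2c(=O)n(C3OC(CO)[C@@H](O)[C@H]3O)c3nc(N)nc(O)c32)c1` gives 3 uM in this assay, the lowest of the three numbers; the steps leading to it are a 15-fold lower number from compound 1 to compound 3 (1.18 log units; beyond the scatter) and a 65-fold lower number from compound 2 to compound 3 (1.81 log units; beyond the scatter).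

Compound 4 `Nc1nc(O)c2c(n1)n(C1OC(CO)[C@@H](O)[C@H]1O)c(=O)n2Cc1ccc([N+](=O)[O-])cc1` has not yet been measured in this assay. It differs from compound 3 by one change: 4-nitrophenyl in place of 3-cyanophenyl on a saturated chain carbon bound to an aromatic nitrogen. For the measured compounds named here, no measured step exchanges one aryl group for another on this carbon; the two steps ending in compound 3 both replace a saturated chain group with 3-cyanophenyl, and both were large in the direction of a lower number. They show that an aryl group at this position goes with the lowest numbers in the series, but they give no direct guide to the size or direction of a change from 3-cyanophenyl to 4-nitrophenyl. The expectation for compound 4 is therefore a step within or only slightly beyond the scatter, a 1.7-fold higher number from compound 3 to compound 4 (0.22 log units; within the scatter), with the direction uncertain. Compound 4 is estimated to give about 5 uM in this assay, with a range from 1.5 uM to 20 uM.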

Compound 4, concentration for half-maximal effect: 40 uM
The estimate for compound 4 lay 8.0-fold (0.90 log units) below the measured number; measured number above the stated range.
By their numbers in this assay, from the lowest: compound 3; then compounds 4 and 1 (each within the scatter of the next); then compound 2.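

An aryl group on this carbon does not by itself bring the low number of compound 3 in this assay: replacing 3-cyanophenyl with 4-nitrophenyl is a large step (a 13-fold higher number from compound 3 to compound 4 (1.12 log units; beyond the scatter)), so the aryl groups at this position are not interchangeable. Against the saturated groups the result splits, since 4-nitrophenyl still stands apart from 2-(dimethylamino)ethyl (a 4.9-fold lower number from compound 2 to compound 4 (0.69 log units; beyond the scatter)) but cannot be told from 1,2-dihydroxyethyl (a 1.1-fold lower number from compound 1 to compound 4 (0.05 log units; within the scatter)), which means that the aryl advantage seen so far holds for 3-cyanophenyl and only partly for 4-nitrophenyl. Nothing at hand gives a reason for the gap between these two aryl groups.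

Still open, as far as these compounds go, is whether the nitrile itself or its number on the ring goes with the low value of compound 3, as 3-cyanophenyl and 4-nitrophenyl differ in both the substituent and its number. Also open, from the compounds shown here alone, is how a plain phenyl group, or a phenyl ring carrying an amine or a carboxylic acid, would stand against 3-cyanophenyl on this carbon.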